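This account rests on a few compounds, and the source may have more. Where it says the series, first, only, none or still open, it means among the compounds named here.

In a physicochemical assay for lipophilicity, at pH 7.4 (a higher number here means a more lipophilic compound, a lower number a more polar compound), compound 1 (`COc1ccc(-c2c(C)nc3c(NCc4ccc(C(N)=O)cc4)cc(C)cn23)cc1OC`) gives 4.3 and compound 2 (`COc1ccc(-c2c(C)nn3c(NCc4ccc(C(N)=O)cc4)nc(C)cc23)cc1OC`) gives 4.8 as the higher of the two numbers, a gap beyond the scatter. Compound 3 (`COc1ccc(-c2c(C)nn3c(NCC4CCOCC4)nc(C)cc23)cc1OC`) differs from compound 2 in one place (oxan-4-yl in place of 4-carbamoylphenyl on a saturated chain carbon bound to a nitrogen on an aromatic ring), where 4-carbamoylbenzyl gives way to (oxan-4-yl)methyl. Among the measured compounds shown here, no measured pair differs in one place only, so the expectation rests on this structural change alone. The expected step (a number 0.20 log units lower from compound 2 to compound 3 (within the scatter)) is small and downward, and it is not expected to go beyond the scatter. For compound 3 the estimated value is 4.6 (expected range 4 to 5.2).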

Compound 3, distribution coefficient: 6.4
For compound 3 the middle estimate is 1.80 log units below the measured one, and the stated range ends below it.
By their numbers in this assay, from the lowest: compound 1; then compound 2; then compound 3.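

In this assay, among the compounds shown here, replacing 4-carbamoylphenyl with oxan-4-yl on a saturated chain carbon bound to a nitrogen on an aromatic ring gives a number 1.60 log units higher from compound 2 to compound 3 (beyond the scatter), showing that this position can carry a large step, which the earlier compounds could not show. This rests on a single pair and sets no pattern. Nothing measured here bears on the reason for the step. The compounds shown leave open how a simple amine, a carboxylic acid or a longer chain would read at this place, and whether the same change gives a similar step on the core of compound 1.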